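The compounds below may be only part of what the source reports. "The series", "measured", "known", "first", "only" and "open" are said of these compounds alone.

Measured compounds:
- compound 1, `CO/C(O)=C1\C(C)=NC(C)=C(C(=O)OCCCN2C(=O)c3ccccc3S2(=O)=O)C1c1ccccc1Cl`: 1.8 nM
- compound 2, `CCO/C(O)=C1\C(C)=NC(C)=C(C(=O)OCCCN2C(=O)c3ccccc3S2(=O)=O)C1c1ccccc1Cl`: 3.9 nM

Going by the values given here, in a functional assay (aorta) with Oryctolagus cuniculus as the target (on this read-out higher numbers stand for weaker inhibition and lower numbers for stronger inhibition), compound 2 holds the higher of the two numbers; its only neighbour is compound 1, reached by a 2.2-fold higher number from compound 1 to compound 2 (0.34 log units; beyond the scatter). Compound 3 is `COCCO/C(O)=C1\C(C)=NC(C)=C(C(=O)OCCCN2C(=O)c3ccccc3S2(=O)=O)C1c1ccccc1Cl`. Its change from compound 2 is methoxy in place of hydrogen on a saturated chain carbon, two bonds along the chain from an oxygen on an unsaturated carbon. Among the compounds with values here, the single comparable step is the chain extension measured as a 2.2-fold higher number from compound 1 to compound 2 (0.34 log units; beyond the scatter), which moved the number modestly upward. A further extension of the same chain is therefore expected to give a small upward move or none beyond the scatter, so the estimate for compound 3 is a 1.4-fold higher number from compound 2 to compound 3 (0.15 log units; within the scatter). Compound 3 is expected to give 5.5 nM in this assay, within 2.2 nM to 14 nM.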

Compound 3, half-maximal inhibitory concentration: 2.9 nM
The estimate for compound 3 lay 1.9-fold (0.28 log units) above the measured number; measured number inside the range.
By their numbers in this assay, from the lowest: compounds 1, 3 and 2 (each within the scatter of the next, the first and the last beyond it).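

In this assay, the methoxy added to the ethyl group of compound 2 gives a shift that stays within the scatter (a 1.3-fold lower number from compound 2 to compound 3 (0.13 log units; within the scatter)). The 2-methoxyethoxy chain of compound 3 also stays within the scatter of the shorter group on compound 1 (a 1.6-fold higher number from compound 1 to compound 3 (0.21 log units; within the scatter)), so at this position the added oxygen and the longer chain produce no readable change in this assay. Nothing available explains this result. Open, going by these compounds, is how an amine, a carboxylic acid or a much longer chain would behave at this position.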